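The compounds below may be only part of what the source reports. "The series", "measured", "known", "first", "only" and "open" are said of these compounds alone.

Of the compounds shown here, three with a shared core have been tested in an assay on HEK293 cells for displacement of a labelled ligand from Neuronal acetylcholine receptor; alpha3/beta4 (Homo sapiens); on this read-out higher numbers stand for weaker inhibition and lower numbers for stronger inhibition. Compound 1 `O=[N+]([O-])c1ccc(Nc2ccc(N3CC4CC(C3)N4)cn2)cc1` gives 25 nM. Compound 2 `O=[N+]([O-])c1ccc(Nc2cncc(N3CC4CC(C3)N4)c2)cc1` gives 0.684 nM, a markedly lower number, and compound 3 `Clc1cccc(Nc2cncc(N3CC4CC(C3)N4)c2)c1` gives 293 nM, a higher one; both gaps to compound 1 lie well beyond the usual scatter, so compound 1 stands second highest of the three. Compound 4 `COc1ccc(Nc2ccc(N3CC4CC(C3)N4)cn2)cc1` has not yet been measured. It differs from compound 1 in one place: methoxy in place of nitro on an aromatic carbon. Within the data shown here, no measured pair shows this exchange directly, so the expectation rests on judgement: the number is expected to rise clearly beyond the scatter, a 24-fold higher number from compound 1 to compound 4 (1.38 log units; beyond the scatter). Compound 4 is therefore estimated at 600 nM, within a range from 100 nM to 4000 nM.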

Compound 4, inhibition constant: 9.03 nM
Estimate against measurement, compound 4: 66-fold (1.82 log units) above, outside the stated range (below it).
By their numbers in this assay, from the lowest: compound 2; then compound 4; then compound 1; then compound 3.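

At this position, on the six-membered aromatic ring of carbon only, methoxy in place of nitro gives a 2.8-fold lower number from compound 1 to compound 4 (0.44 log units; beyond the scatter) and so shows that nitro is not needed here for a low number. A smaller group, with no double bond outside aromatic rings, does at least as well on this core. Nothing measured here explains this change. From the compounds shown here alone, whether an amine or a longer chain such as ethoxy at this position would lower the number further remains open. So does whether methoxy would have the same effect on the core of compound 2.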